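The source may report more compounds than this note shows. Statements on the series, on what has been measured and on what is new or still open speak of the compounds shown alone.

Of the compounds shown here, three have so far been tested in a functional assay on MOLT-4 cells (Homo sapiens) for cytotoxicity; a higher number here means a weaker inhibitor, a lower number a stronger inhibitor. Compound 1 (`O=S(=O)(N/C(=N\O)Nc1ccc(Cl)cc1)c1cc(C(F)(F)F)cc(C(F)(F)F)c1`) gives 44 ug/mL, compound 2 (`Cc1c(S(=O)(=O)N/C(=N\O)Nc2ccc(Cl)cc2)sc2ccc(Cl)cc12`) gives 38 ug/mL, and compound 3 (`O=S(=O)(N/C(=N\O)Nc1ccc(Cl)cc1)c1cc(S(=O)(=O)c2ccccc2)cs1`) gives 22 ug/mL. Compound 2 lies within the usual scatter of both of the others, so these numbers do not separate it from either one. All three carry the same 4-chlorophenyl group and differ on the sulfonyl side.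

Compound 4 (`Cc1c(S(=O)(=O)N/C(=N\O)Nc2ccc(Cl)c(Cl)c2)sc2ccc(Cl)cc12`) keeps the sulfonyl side of compound 2 and changes only the 4-chlorophenyl group: chloro in place of hydrogen on an aromatic carbon. This places chloro in place of hydrogen on an aromatic carbon, giving a 3,4-dichlorophenyl group. For the measured compounds named here, no measured pair shows this change, so the only anchor is compound 2 at 38 ug/mL. The expected step is small, a 1.3-fold lower number from compound 2 to compound 4 (0.10 log units; within the scatter), leaning toward a lower number and probably staying within the scatter. For compound 4 the estimated value in this assay is 30 ug/mL, with an expected range of 14 ug/mL to 60 ug/mL.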

Compound 4, half-maximal inhibitory concentration: > 300 ug/mL
Compound 4 gave a limit, no number; the forecaster's own chance of this, stated with the estimate: 5%; at least 10-fold (1.00 log units) between middle value and limit.
By their numbers in this assay, from the lowest: compounds 3, 2 and 1 (each within the scatter of the next). At a limit, above all of these: compound 4.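

In this assay, compound 4 gives > 300 ug/mL, which is a limit of the assay and not a number. The earlier compounds shown here all carried the 4-chlorophenyl group, so they could not show whether this part of the molecule matters; the single added chloro that makes the 3,4-dichlorophenyl group gives an at least 7.8-fold higher number from compound 2 to compound 4 (0.89 log units; beyond the scatter). On these data alone, this position on the ring is therefore not neutral: one chlorine here shifts the read-out toward a weaker inhibitor, and the full size of the shift stays unknown: the limit of > 300 ug/mL in this assay, at which 1 of the 4 values shown sits.

Whether any group at this carbon would do the same remains open, as the compounds shown hold only hydrogen or chloro there, and a fluoro, methyl or methoxy group would help to tell. The change is also seen on one sulfonyl side only, leaving open how it behaves with the sulfonyl sides of compound 1 and compound 3.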